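The source may report more compounds than this note shows. Statements on the series, on what has been measured and on what is new or still open speak of the compounds shown alone.

Compound 1 `COc1ccc(-c2nc(/C=C/c3cc4ccccc4nc3OC)no2)cc1` — in an ADME assay on HepG2 cells (Homo sapiens) for cytotoxicity, read by sulforhodamine B assay, with a stated time of 48 h (a higher number here means that more compound is tolerated, a lower number that less compound is tolerated), compound 1 gives > 220000 nM, which is a limit of the assay and not a number.
Compound 2 `COc1cccc(-c2nc(/C=C/c3cc4ccccc4nc3OC)no2)c1` — in this assay compound 2 gives > 220000 nM, again a limit of the assay.
Compound 3 `COc1nc2ccccc2cc1/C=C/c1noc(C)n1` — not yet measured in this assay.

Compound 2 stands only at a limit in this assay, so no number is known for it. For the measured compounds named here, the same holds for the one other value shown, that of compound 1 (the limit of > 220000 nM in this assay, at which 2 of the 2 values shown sit). Going by the values given here, the single measured step, a step that the two limits leave unreadable from compound 1 to compound 2, is unreadable in size, since both ends are limits.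

Compound 3 differs from compound 2 by methyl in place of 3-methoxyphenyl on an aromatic carbon. No measured step touches this position, and the one step shown gives no size at all, so no step beyond the scatter is expected in this assay. Compound 3 is expected at 250000 nM, with a range from 80000 nM to 600000 nM. The expected step is a step that the limit leaves unreadable from compound 2 to compound 3, and a limit rather than a number is the likely outcome.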

Compound 3, half-maximal cytotoxic concentration: > 300000 nM
Compound 3 was reported as a limit; the forecaster's own chance of this, stated with the estimate: 80%; middle value at least 1.2-fold (0.07 log units) from the limit.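

In this assay compound 3 gives > 300000 nM, a limit of the assay and not a number. For the compounds shown here, compound 1 and compound 2 also stand at limits, so no step among the three can be read. Left open is whether methyl, 3-methoxyphenyl and 4-methoxyphenyl differ at all in this assay.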